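Chloro added ortho on the benzyl of compound 3

The source may hold more compounds than are shown below. What is called first, only, known or untested is meant among the compounds shown, and "the series" means these compounds.

Measured so far:
compound 1 `CNc1nc(-c2ccccc2)nc2c1nnn2Cc1ccccc1Cl`: 191 nM
compound 2 `CCNc1nc(-c2ccccc2)nc2c1nnn2Cc1ccccc1Cl`: 463 nM
compound 3 `CCCCCCNc1nc(-c2ccccc2)nc2c1nnn2Cc1ccccc1`: 13.2 nM

In an assay on Cerebral cortex for displacement of a labelled ligand from adenosine receptor A1 (Bos taurus) (on this read-out lower numbers stand for stronger inhibition and higher numbers for weaker inhibition), compound 3 gives the lowest number of the three; compound 1 lies above it, and compound 2 higher still, both gaps beyond the scatter. Among the compounds with values here, the only single-point step among the measured compounds is a 2.4-fold higher number from compound 1 to compound 2 (0.38 log units; beyond the scatter), which concerns the chain on the ring nitrogen, not the benzyl.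

Compound 4 `CCCCCCNc1nc(-c2ccccc2)nc2c1nnn2Cc1ccccc1Cl` takes compound 3 and makes one change: chloro in place of hydrogen on an aromatic carbon. Within the data shown here, no measured pair differs only in this chloro; compounds 1 and 2 both carry it while compound 3 does not, but they also differ from compound 3 in the chain, so the chloro contribution cannot be read off. Among the measured compounds shown here, there is thus no step that bears directly on this change, and the working expectation is a step in this assay that stays within the scatter, in either direction. Compound 4 is therefore expected to give 12 nM, with a range from 4 nM to 35 nM. This estimate means a step of a 1.1-fold lower number from compound 3 to compound 4 (0.04 log units; within the scatter), and the measured value will decide.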

Compound 4, inhibition constant: 31 nM
Compound 4: middle estimate off by 2.6-fold (0.41 log units), on the low side; the measured number falls inside the stated range.
By their numbers in this assay, from the lowest: compound 3; then compound 4; then compound 1; then compound 2.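

Working from the chain of compound 3, benzyl to 2-chlorobenzyl gives the first isolated reading of this chloro in this assay, and the change weakens binding modestly (a 2.3-fold higher number from compound 3 to compound 4 (0.37 log units; beyond the scatter)). With the 2-chlorobenzyl held fixed, the chain on the nitrogen matters more, since the longer chain of compound 4 gives both a large step (a 15-fold lower number from compound 2 to compound 4 (1.17 log units; beyond the scatter)) and a modest one (a 6.2-fold lower number from compound 1 to compound 4 (0.79 log units; beyond the scatter)), each toward a lower number and each outweighing the loss from the chloro. The chain trend is not uniform, however: compound 2 goes against it, with its added methyl moving the number upward (a 2.4-fold higher number from compound 1 to compound 2 (0.38 log units; beyond the scatter)).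

No supporting data are available to explain the direction or size of the chloro step or the chain steps. From the compounds shown here alone, it remains open whether the chloro step carries over to the shorter chains of compound 1 and compound 2, and what a fluoro or methoxy group on the benzyl, or a longer chain or a cyclohexyl group on the nitrogen, would give.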